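A few compounds are considered here, and "the series" means these few. Any claim that something is new, unique, unknown or untested is made for them only; others in the source may bear on it.

Measured so far:
compound 1 `COc1ccc(CN2CCC[C@H]2COC(c2ccccc2)c2ccc(Cl)cc2)cc1` — 30000 nM
compound 2 `COc1ccc(CCCN2CCC[C@H]2COC(c2ccccc2)c2ccc(Cl)cc2)cc1` — 10000 nM

In a functional assay on MDA-MB-361 cells (Homo sapiens) for inhibition, read by calcium flux (a higher number here means a weaker inhibitor, a lower number a stronger inhibitor), compound 1 gives 30000 nM and compound 2 gives 10000 nM. For the measured compounds named here, compound 2 stands lowest of the two numbers; its only neighbour is compound 1, reached by a 3.0-fold lower number from compound 1 to compound 2 (0.48 log units; beyond the scatter). Going by the values given here, that is the sole measured step, and it shows that replacing 4-methoxyphenyl with 2-(4-methoxyphenyl)ethyl on the saturated chain carbon bound to the amine nitrogen in the ring lowers the number.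

Compound 3 `CN1CCC[C@H]1COC(c1ccccc1)c1ccc(Cl)cc1` is not yet measured. It differs from compound 2 by hydrogen in place of 2-(4-methoxyphenyl)ethyl on a saturated chain carbon bound to an amine nitrogen in a ring. Among the compounds with values here, the one measured step runs the other way, removing the aromatic group entirely rather than extending it, so it bears on this change only by direction: the smaller group at that position went with the higher number. Compound 3 is therefore expected to give a higher number, a step of a 4.0-fold higher number from compound 2 to compound 3 (0.60 log units; beyond the scatter) in this assay. The estimate for compound 3 is 40000 nM, within 10000 nM to 150000 nM.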

Compound 3, half-maximal inhibitory concentration: 100000 nM
Beside the measured number, compound 3's estimate is 2.5-fold (0.40 log units) below it; low and high end bracket the measured number.
By their numbers in this assay, from the lowest: compound 2; then compound 1; then compound 3.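

In this assay, the full loss of the aromatic group from the saturated chain carbon bound to an amine nitrogen in a ring gives a 10-fold higher number from compound 2 to compound 3 (1.00 log units; beyond the scatter) and shows that the 2-(4-methoxyphenyl)ethyl group contributes to inhibition in this series. The shorter substituent also counts, since hydrogen in place of 4-methoxyphenyl gives a 3.3-fold higher number from compound 1 to compound 3 (0.52 log units; beyond the scatter) in the same direction. Across these three compounds the number falls from hydrogen to 4-methoxyphenyl to 2-(4-methoxyphenyl)ethyl, with no compound going against that order, and no available evidence accounts for it.

As far as these compounds go, whether a longer chain between the amine nitrogen and the aromatic ring would lower the number further remains open. So does the part played by the methoxy group, which could be tested with a carboxylic acid or an amine in its place.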